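Ester variation on a nucleoside-like core: cytotoxicity notes

This account rests on a few compounds, and the source may have more. Where it says the series, first, only, none or still open, it means among the compounds named here.

Measured compounds:
- compound 1 `COCCOC(=O)C(O)Cn1cnc2c(N)ncnc21`: > 400 ug/mL
- compound 2 `CCCOC(=O)C(O)Cn1cnc2c(N)ncnc21`: > 400 ug/mL
- compound 3 `CC(C)COC(=O)C(O)Cn1cnc2c(N)ncnc21`: > 400 ug/mL

In a functional assay on Vero cells (Chlorocebus sabaeus) for cytotoxicity (a lower number here means that less compound is tolerated, a higher number that more compound is tolerated), compound 1 reaches only a limit of the assay, > 400 ug/mL, not a measured number. The same holds for compound 2, whose value in this assay is a limit. For compound 3 the value in this assay is a limit as well. All three therefore sit at the limit of > 400 ug/mL in this assay, at which 3 of the 3 values shown sit, and the steps between them cannot be read: a step that the two limits leave unreadable from compound 1 to compound 2, a step that the two limits leave unreadable from compound 1 to compound 3 and a step that the two limits leave unreadable from compound 2 to compound 3 give no size or direction.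

Compound 4 `CCC(C)OC(=O)C(O)Cn1cnc2c(N)ncnc21` is not yet measured. It differs from compound 1 as follows: sec-butyl in place of 2-methoxyethyl on an oxygen next to a carbonyl group. Of the measured steps, the ones from compound 1 to compound 2 and from compound 1 to compound 3 also exchange the group on the oxygen next to the carbonyl group, but both are unreadable, so no size can be carried over. With every neighbour at the limit, compound 4 is expected to stay there too, giving an estimated 400 ug/mL (range 200 ug/mL to 800 ug/mL). The expected step is then a number no higher from compound 1 to compound 4 (the limit leaves the size open).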

Compound 4, minimum cytotoxic concentration: > 400 ug/mL
Compound 4: no number, only a limit; the forecaster's own chance of this, stated with the estimate: 85%; the middle value lies on the limit itself.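

Compound 4 stays at a limit in this assay, like compound 1, compound 2 and compound 3, so no step involving compound 4 can be read: the limit of > 400 ug/mL in this assay, at which 4 of the 4 values shown sit.

The compounds shown leave open whether any ester group here changes cytotoxicity, and what real value lies behind each limit.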